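The compounds below may be only part of what the source reports. "The series", "measured", "known", "first", "only" and "open" are said of these compounds alone.

In a functional assay on HCT-116 cells (Homo sapiens) for cytotoxicity, read by MTT assay, with a stated time of 48 h (on this read-out lower numbers stand for stronger inhibition and higher numbers for weaker inhibition), compound 1 `Cc1ccc(-c2nn(-c3ccccc3)cc2C(=O)Nc2ccccc2)cc1` gives 2360 nM. Compound 2 `COc1ccc(NC(=O)c2cn(-c3ccccc3)nc2-c2ccc(C)cc2)cc1` gives 1450 nM, and compound 3 `CCOc1ccc(NC(=O)c2cn(-c3ccccc3)nc2-c2ccc(C)cc2)cc1` gives 780 nM. The step of a 1.6-fold lower number from compound 1 to compound 2 (0.21 log units; within the scatter) stays within the scatter, whereas a 3.0-fold lower number from compound 1 to compound 3 (0.48 log units; beyond the scatter) lies beyond it, and a 1.9-fold lower number from compound 2 to compound 3 (0.27 log units; within the scatter) again stays within it; compound 1 is thus clearly weaker than compound 3 alone. Compound 4 `O=C(Nc1ccccc1)c1cn(-c2ccccc2)nc1-c1ccc(Cl)cc1` differs from compound 1 in a different place: chloro in place of methyl on an aromatic carbon. For the measured compounds named here, none of the measured steps touches that aromatic carbon; all three alter the other aryl ring, so they offer no direct guide, and no step beyond the scatter is expected in this assay. Compound 4 is therefore expected to give 2000 nM, between 800 nM and 5000 nM, a step of a 1.2-fold lower number from compound 1 to compound 4 (0.07 log units; within the scatter).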

Compound 4, half-maximal inhibitory concentration: 2180 nM
Compound 4: the middle estimate sits 1.1-fold (0.04 log units) below what was measured; the range from low to high includes it.
By their numbers in this assay, from the lowest: compounds 3, 2, 4 and 1 (each within the scatter of the next, the first and the last beyond it).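

Chloro in place of methyl is the first change shown on this ring, and in this assay it gives a 1.1-fold lower number from compound 1 to compound 4 (0.03 log units; within the scatter), so the two groups cannot be told apart here. The earlier compounds changed only the other aryl ring, whereas this position has so far shown no step beyond the scatter. No measurement here explains this result. On these data alone, whether an amine, a carboxylic acid or a longer chain at this place would shift the number stays open. So does whether chloro would give the same result alongside the ethoxy group of compound 3.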